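Compound 3: an expected step from compound 1

The compounds below may be only part of what the source reports. "The series", "measured", "known", "first", "only" and "open" are said of these compounds alone.

In an ADME assay for pharmacokinetics (a higher number here means that the compound lasts longer, a lower number that the compound disappears faster), compound 1 `Cc1ncc2cc(-c3c(Cl)cccc3Cl)c(NC(=O)c3cccnc3)nc2n1` gives 4 h and compound 2 `COC(=O)Nc1nc2nc(C)ncc2cc1-c1c(Cl)cccc1Cl` gives 6 h, which places the two within the scatter of each other. Compound 3 `CC(=O)N(C)c1nc2nc(C)ncc2cc1-c1c(Cl)cccc1Cl` is unmeasured and differs from compound 1 as follows: acetyl(methyl)amino in place of ((pyridin-3-yl)carbonyl)amino on an aromatic carbon. For the measured compounds named here, one measured step bears on this change: a 1.5-fold higher number from compound 1 to compound 2 (0.18 log units; within the scatter), with methoxy in place of pyridin-3-yl on a carbonyl carbon. Neither measured compound carries acetyl(methyl)amino, so the evidence is thin, and no step beyond the scatter is expected in this assay. The expected step is a 1.3-fold higher number from compound 1 to compound 3 (0.10 log units; within the scatter). The estimate for compound 3 is 5 h, with an expected range of 2.5 h to 10 h.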

Compound 3, half-life: 1.6 h
Compound 3: middle estimate off by 3.1-fold (0.49 log units), on the high side; measured number below the stated range.
By their numbers in this assay, from the lowest: compound 3; then compounds 1 and 2 (each within the scatter of the next).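

In this assay, this aromatic carbon proves sensitive to the group it carries: acetyl(methyl)amino gives a 2.5-fold lower number from compound 1 to compound 3 (0.40 log units; beyond the scatter) and a 3.8-fold lower number from compound 2 to compound 3 (0.57 log units; beyond the scatter), whereas the earlier change on the carbonyl carbon stayed within the scatter. Compound 3 is the only compound shown with no hydrogen-bond donor in this group, but its change also replaces the rest of the group, so the two parts cannot be separated. Nothing available explains the lower number. Open, going by these compounds, is whether plain acetylamino, without the methyl, keeps the numbers of compound 1 and compound 2. Also open, on these data alone, is how a simple amine or a longer acyl chain behaves at this position.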